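Cyclohexyl for 4-methylphenyl: cytotoxicity outlook for compound 4

The source may report more compounds than this note shows. Statements on the series, on what has been measured and on what is new or still open speak of the compounds shown alone.

Compound 1 `CCC1(Cc2ccccc2)OS(=O)(=O)C=C1OCc1ccc(C)cc1` is the reference point of this set. In an ADME assay on HEL cells (Homo sapiens) for cytotoxicity, with a stated time of 3 days (on this read-out higher numbers stand for lower toxicity in this test and lower numbers for higher toxicity in this test), compound 1 gives >= 16000 nM, which is a limit of the assay rather than a number. Compound 2 `CCC1(CC)OS(=O)(=O)C=C1OCc1ccccc1` gives > 400000 nM in this assay, again only a limit. Compound 3 `CCCC1(Cc2ccccc2)OS(=O)(=O)C=C1OCc1ccccc1` gives >= 400000 nM in this assay, also a limit. For the measured compounds named here, the record thus holds nothing but limits, as the limit of > 400000 nM in this assay, at which 1 of the 3 values shown sits, the limit of >= 16000 nM in this assay, at which 1 of the 3 values shown sits, and the limit of >= 400000 nM in this assay, at which 1 of the 3 values shown sits, show, so no step between measured compounds can be stated, and compound 1 stands on a limit with no number of its own to compare.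

Compound 4 `CCC1(Cc2ccccc2)OS(=O)(=O)C=C1OCC1CCCCC1` differs from compound 1 in one place: cyclohexyl in place of 4-methylphenyl on a saturated chain carbon bound to an oxygen on an unsaturated carbon. Going by the values given here, with every value at a limit and no measured step to lean on, no change beyond the scatter is expected in this assay. The step expected from this change is a step that the limit leaves unreadable from compound 1 to compound 4. Compound 4 is estimated at 100000 nM, within 16000 nM to 400000 nM, and is expected to come back as a limit once more.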

Compound 4, minimum cytotoxic concentration: >= 200000 nM
Compound 4: only a limit was reported; the forecaster's own chance of this, stated with the estimate: 85%; middle value at least 2.0-fold (0.30 log units) away from the limit.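

In this assay compound 4 gives >= 200000 nM, a limit of the assay. For the compounds shown here, compound 1 gives >= 16000 nM, also a limit, so no step from compound 1 to compound 4 can be read. On these data alone, whether cyclohexyl in place of 4-methylphenyl shifts the minimum cytotoxic concentration at all stays open.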